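Solubility of a tetrahydroquinoline analogue, estimated

This account rests on a few compounds, and the source may have more. Where it says the series, first, only, none or still open, it means among the compounds named here.

Compound 1 `COc1ccc2[nH]c(C(=O)N3CC(=O)N(Cc4ccccc4)[C@@H](CN4CC5CC5C4)C3)cc2c1` gives 17500 nM in a physicochemical assay for solubility, read by spectrophotometry, in phosphate buffer, with a stated time of 2 h, at pH 7.4; on this read-out lower numbers stand for lower solubility and higher numbers for higher solubility.
Compound 2 `COc1ccc2[nH]c(C(=O)N3CC(=O)N(Cc4ccccc4)[C@@H](CN4CCn5cccc5C4)C3)cc2c1` gives 29700 nM in this assay.

Compound 2 stands highest of the two numbers, but its nearest neighbour, compound 1, lies within the scatter of it. Compound 3 `COc1ccc2[nH]c(C(=O)N3CC(=O)N(Cc4ccccc4)[C@@H](CN4CCCc5ccccc54)C3)cc2c1` differs from compound 2 by a group of 10 heavy atoms (9 carbon, 1 nitrogen; one six-membered non-aromatic ring with 1 hetero atom, one six-membered aromatic ring of carbon only) in place of a group of 9 heavy atoms (7 carbon, 2 nitrogen; one five-membered aromatic ring with 1 hetero atom, one six-membered non-aromatic ring with 2 hetero atoms), on a saturated chain carbon bound to a saturated ring carbon. For the measured compounds named here, the only measured step that bears on this change is a 1.7-fold higher number from compound 1 to compound 2 (0.23 log units; within the scatter), a swap at the same place that did not move the number beyond the scatter. Compound 3 is therefore expected to show no step beyond the scatter, a 1.5-fold lower number from compound 2 to compound 3 (0.17 log units; within the scatter). Compound 3 is estimated at 20000 nM, within 7000 nM to 50000 nM.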

Compound 3, solubility: 8500 nM
Beside the measured number, compound 3's estimate is 2.4-fold (0.37 log units) above it; measured number inside the range.
By their numbers in this assay, from the lowest: compound 3; then compounds 1 and 2 (each within the scatter of the next).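

In this assay, for the compounds shown here, the 1,2,3,4-tetrahydroquinolin-1-yl group brings the first change at this place that lies beyond the scatter, both against compound 2 (a 3.5-fold lower number from compound 2 to compound 3 (0.54 log units; beyond the scatter)) and against compound 1 (a 2.1-fold lower number from compound 1 to compound 3 (0.31 log units; beyond the scatter)). Both steps are modest, but they show that the group on this saturated chain carbon can move the number, which the swap between the two earlier groups did not show. Nothing measured here gives a reason for these steps.

As far as these compounds go, whether a piperidine or a morpholine at this place would match compound 3 or the two earlier compounds remains open.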